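This account rests on a few compounds, and the source may have more. Where it says the series, first, only, none or still open, it means among the compounds named here.

Measured in a functional assay on HeLa cells (Homo sapiens) for antiproliferative activity, read by MTT assay, with a stated time of 72 h; a higher number here means a weaker inhibitor, a lower number a stronger inhibitor:

- Compound 1 `COc1ccc(N2C(=O)COc3ccc(-c4cnc(Cl)c(NS(=O)(=O)c5ccc(F)cc5)c4)cc32)cc1`: 8320 nM
- Compound 2 `CC(C)N1C(=O)COc2ccc(-c3cccc(NS(=O)(=O)c4ccc(F)cc4)c3)cc21`: 22700 nM
- Compound 3 `O=C1COc2ccc(-c3cnc4ccccc4c3)cc2N1C1CCCCC1`: 19700 nM

Compound 3, at 19700 nM, cannot be told apart from compound 2, at 22700 nM. The two values lie within the usual scatter of repeated measurements. Compound 1, at 8320 nM, has a lower number than compound 3, and that gap lies beyond the scatter.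

Compound 4 `O=C1COc2ccc(-c3cnc4ccccc4c3)cc2N1` has hydrogen in place of cyclohexyl on an amide-type nitrogen in a ring. Among the measured compounds shown here, all three measured compounds carry a group on this nitrogen, and no measured pair isolates the change, so the data offer no direct guide to its effect. In this assay, a small move towards a higher number, meaning a weaker inhibitor, is expected, and it may not exceed the scatter. The expected change is a 1.5-fold higher number from compound 3 to compound 4 (0.18 log units; within the scatter). The estimate for compound 4 is 30000 nM, with an expected range of 10000 nM to 90000 nM.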

Compound 4, half-maximal inhibitory concentration: > 40000 nM
Compound 4: no number, only a limit; the forecaster's own chance of this, stated with the estimate: 30%; at least 1.3-fold (0.12 log units) between middle value and limit.
By their numbers in this assay, from the lowest: compound 1; then compounds 3 and 2 (each within the scatter of the next). At a limit, above all of these: compound 4.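

Among the compounds shown here, the pair of compounds measured in this assay is the first to differ only on the amide-type nitrogen in a ring, and hydrogen in place of cyclohexyl brings an at least 2.0-fold higher number from compound 3 to compound 4 (0.30 log units; that floor lies within the scatter) and no sign of a gain. Going by these compounds, the true size of this change remains unknown, since only its floor can be read, and the real shift could be small or large. Compound 4 gives > 40000 nM as a limit of the assay and not a number, the only such value among these compounds: the limit of > 40000 nM in this assay, at which 1 of the 4 values shown sits.

On these data alone, whether a small methyl group on this nitrogen would be enough to bring back a measurable number remains open. It is also unclear how an open hexyl chain, or a chain ending in an amine, would compare with cyclohexyl at this position on the same core.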